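Chain length variation on the basic side chain

A few compounds are considered here, and "the series" means these few. Any claim that something is new, unique, unknown or untested is made for them only; others in the source may bear on it.

Measured compounds:
compound 1, `O=c1c2ccccc2c(Cc2ccc(Cl)cc2)nn1C1CCCN(Cc2ccc(OCCCN3CCCCCC3)cc2)CC1`, 100 nM
compound 2, `CN(C)CCn1nc(Cc2ccc(Cl)cc2)c2ccccc2c1=O`, 158 nM
compound 3, `COc1ccc(Cc2nn(C[C@H]3CCCN3C)c(=O)c3ccccc23)cc1`, 126 nM

The series shares one core and varies the substituent on the ring nitrogen. In an assay for binding affinity to Alpha-1A adrenergic receptor (Homo sapiens) (on this read-out lower numbers stand for stronger inhibition and higher numbers for weaker inhibition), compound 1 gives 100 nM, compound 2 gives 158 nM and compound 3 gives 126 nM. The number for compound 2 is nominally the highest of the three, but the values of compound 3 and compound 1 both lie within the scatter of it, so the three compounds cannot be ranked on these data.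

Compound 4, `CN(C)CCCn1nc(Cc2ccc(Cl)cc2)c2ccccc2c1=O`, has not yet been measured in this assay. It differs from compound 2 by (dimethylamino)methyl in place of dimethylamino on a saturated chain carbon, two bonds along the chain from an aromatic nitrogen. Three quite different side chains already give indistinguishable numbers, so a one-carbon extension of the chain is expected to move the value little, in no clear direction. The expected step of a 1.1-fold lower number from compound 2 to compound 4 (0.05 log units; within the scatter) is therefore within the scatter. Compound 4 is estimated at 140 nM, with a range from 50 nM to 400 nM.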

Compound 4, inhibition constant: 316 nM
Beside the measured number, compound 4's estimate is 2.3-fold (0.35 log units) below it; low and high end bracket the measured number.
By their numbers in this assay, from the lowest: compounds 1, 3, 2 and 4 (each within the scatter of the next, the first and the last beyond it).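

Among these compounds, compound 2 and compound 4 form the only pair that differs in one place, so this is the first direct reading of chain length on the aromatic nitrogen. In this assay, the change from 2-(dimethylamino)ethyl to 3-(dimethylamino)propyl gives a 2.0-fold higher number from compound 2 to compound 4 (0.30 log units; within the scatter) and so cannot be separated from repeat-measurement noise. On this pair alone, chain length at this position has no resolved effect on the read-out, and nothing available here bears on the size of the step.

A longer chain such as 4-(dimethylamino)butyl, or a piperidine in place of the dimethylamino group on the same chain, could still give a step beyond the scatter. On these data alone, it also remains open whether the same chain change reads alike with a methoxy group in place of the chlorine.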